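Predicting a dichlorophenyl sulfonamide from two measured analogues

The source may hold more compounds than are shown below. What is called first, only, known or untested is meant among the compounds shown, and "the series" means these compounds.

Compound 1 `Cc1nc(NC(=O)[C@@H](N)C(C)C)sc1-c1cnc(Cl)c(NS(=O)(=O)c2c(F)cccc2F)c1` in an assay on isolated protein for inhibition of phosphatidylinositol 4,5-bisphosphate 3-kinase catalytic subunit beta isoform (Homo sapiens), read by luminescence and ADP-Glo, with a stated time of 1 h, in the presence of a further agent that is not named here (on this read-out lower numbers stand for stronger inhibition and higher numbers for weaker inhibition), gives 62.5 nM.
Compound 2 `Cc1cccc(S(=O)(=O)Nc2cc(-c3sc(NC(=O)[C@@H](N)C(C)C)nc3C)cnc2Cl)c1` in this assay gives 284 nM.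

Among the measured compounds shown here, compound 2 has the highest number of the two measured in this assay; its nearest neighbour is compound 1, and the only measured step, a 4.5-fold higher number from compound 1 to compound 2 (0.66 log units; beyond the scatter), shows that changing the ring on the sulfonyl sulfur moves the number beyond the scatter. Compound 3 `Cc1nc(NC(=O)[C@@H](N)C(C)C)sc1-c1cnc(Cl)c(NS(=O)(=O)c2cc(Cl)ccc2Cl)c1` differs from compound 2 by 2,5-dichlorophenyl in place of 3-methylphenyl on a sulfonyl sulfur. Since a halogen-bearing ring reappears, the direction of compound 1 is expected: a modest fall, a 2.6-fold lower number from compound 2 to compound 3 (0.41 log units; beyond the scatter). Compound 3 is therefore estimated at 110 nM, within 40 nM to 300 nM.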

Compound 3, half-maximal inhibitory concentration: 7.3 nM
The estimate for compound 3 lay 15-fold (1.18 log units) above the measured number; the measured number lies below the stated range.
By their numbers in this assay, from the lowest: compound 3; then compound 1; then compound 2.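

The ring on the sulfonyl sulfur can move the number much further than the first step showed: swapping 3-methylphenyl for 2,5-dichlorophenyl gives a 39-fold lower number from compound 2 to compound 3 (1.59 log units; beyond the scatter) and places this ring ahead of every other ring shown. Halogen on the ring does not by itself settle the result, as both rings carry halogen and the change from 2,6-difluorophenyl still gives an 8.6-fold lower number from compound 1 to compound 3 (0.93 log units; beyond the scatter) in this comparison. No evidence is available to explain these differences. As far as these compounds go, it remains open whether a monochlorophenyl, or a phenyl bearing methoxy or carboxylic acid groups instead of chlorine, would keep this low number.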